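This account rests on a few compounds, and the source may have more. Where it says the series, first, only, none or still open, it means among the compounds named here.

Three compounds sharing one core were measured in an assay on isolated protein for displacement of a labelled ligand from metabotropic glutamate receptor 5 (Homo sapiens), with a stated time of 60 min, tested at 1 uM; on this read-out lower numbers stand for less inhibition and higher numbers for more inhibition at the one concentration tested (going by the name of the read-out). Compound 1 `COc1ccc2ncc(S(=O)(=O)c3cc(F)cc(F)c3)c(N3CCC(C)CC3)c2c1` gives 30%, compound 2 `COc1ccc2ncc(S(=O)(=O)c3ccc(F)cc3)c(N3CCC(C)CC3)c2c1` gives 27%, and compound 3 `COc1cccc(S(=O)(=O)c2cnc3ccc(OC)cc3c2N2CCC(C)CC2)c1` gives 0%, the lowest of the three. The steps of a number 30 percentage points lower from compound 1 to compound 3 (beyond the scatter) and a number 27 percentage points lower from compound 2 to compound 3 (beyond the scatter) both run downward when 3-methoxyphenyl enters on the sulfonyl sulfur, whereas the step of a number 3 percentage points lower from compound 1 to compound 2 (within the scatter) is within the scatter. Compound 4 `COc1ccc2ncc(S(=O)(=O)c3ccc(C)c(F)c3)c(N3CCC(C)CC3)c2c1` differs from compound 3 by 3-fluoro-4-methylphenyl in place of 3-methoxyphenyl on a sulfonyl sulfur. Because compound 1 shows a number 30 percentage points lower from compound 1 to compound 3 (beyond the scatter) and compound 2 shows a number 27 percentage points lower from compound 2 to compound 3 (beyond the scatter) on returning from a fluorine-bearing phenyl, a rise beyond the scatter is expected for compound 4. Compound 4 is therefore estimated at 25%, with a range from 5% to 50%. This estimate means an expected step of a number 25 percentage points higher from compound 3 to compound 4 (beyond the scatter).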

Compound 4, a percentage reported as inhibition, at one concentration (the size of the read-out at that concentration, not a potency): 73%
Estimate against measurement, compound 4: 48 percentage points below; measured number outside the range, above it.
By their numbers in this assay, from the lowest: compound 3; then compounds 2 and 1 (each within the scatter of the next); then compound 4.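

In this assay, for the compounds shown here, the group on the sulfonyl sulfur proves able to raise the number well past anything the earlier compounds showed, with a number 73 percentage points higher from compound 3 to compound 4 (beyond the scatter) and a number 46 percentage points higher from compound 2 to compound 4 (beyond the scatter) and also a number 43 percentage points higher from compound 1 to compound 4 (beyond the scatter) when 3-fluoro-4-methylphenyl enters. Fluorine on this phenyl ring is not enough on its own to reach that level, since compound 1 and compound 2 also bear it. Nothing available explains the gain. As far as these compounds go, whether the methyl or the fluorine of 3-fluoro-4-methylphenyl matters more remains open. Also open, from the compounds shown here alone, is how an amine or a carboxylic acid on this ring would fare.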